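The source may hold more compounds than are shown below. What is called first, only, known or untested is meant among the compounds shown, and "the series" means these compounds.

Measured so far in a functional assay on NCI-H460 cells (Homo sapiens) for cytotoxicity, read by MTT assay, with a stated time of 72 h; a lower number here means a stronger inhibitor, a higher number a weaker inhibitor:

compound 1 `COc1ccc(/C=N/NC(=O)Nc2ccc(Oc3ccnc(-c4nncn4CCN(C)C)c3)c(F)c2)c(OC)c1` — 1570 nM
compound 2 `CN(C)CCn1cnnc1-c1cc(Oc2ccc(NC(=O)N/N=C/c3ccccc3)cc2F)ccn1` — 1780 nM
compound 3 `CN(C)CCn1cnnc1-c1cc(Oc2ccc(NC(=O)N/N=C/c3ccc(F)cc3F)cc2F)ccn1` — 1930 nM

Compound 3 carries the highest of the three numbers in this assay, yet its gaps to compound 2 and compound 1 both sit within the scatter, so no order among the three can be claimed. Compound 4 `CN(C)CCn1cnnc1-c1cc(Oc2ccc(NC(=O)N/N=C/c3cccc(Br)c3)cc2F)ccn1` differs from compound 3 only in that (3-bromophenyl in place of 2,4-difluorophenyl on a carbon with a double bond to nitrogen). For the measured compounds named here, every step so far that alters the aryl group on that carbon bears on this change: a 1.1-fold higher number from compound 1 to compound 2 (0.05 log units; within the scatter), a 1.2-fold higher number from compound 1 to compound 3 (0.09 log units; within the scatter) and a 1.1-fold higher number from compound 2 to compound 3 (0.04 log units; within the scatter) were all within the scatter, with no direction that holds up. On that basis no step beyond the scatter is expected from compound 3 to compound 4, that is a 1.0-fold lower number from compound 3 to compound 4 (0.01 log units; within the scatter). Compound 4 is therefore estimated at 1900 nM, with a range of 900 nM to 4000 nM.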

Compound 4, half-maximal inhibitory concentration: 520 nM
The estimate for compound 4 lay 3.7-fold (0.56 log units) above the measured number; the measured number lies below the stated range.
By their numbers in this assay, from the lowest: compound 4; then compounds 1, 2 and 3 (each within the scatter of the next).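

In this assay the aryl group on the carbon with a double bond to nitrogen now gives steps beyond the scatter, all modest (a 3.7-fold lower number from compound 3 to compound 4 (0.57 log units; beyond the scatter)) (a 3.4-fold lower number from compound 2 to compound 4 (0.53 log units; beyond the scatter)) (a 3.0-fold lower number from compound 1 to compound 4 (0.48 log units; beyond the scatter)). Phenyl, 2,4-difluorophenyl and 2,4-dimethoxyphenyl had not separated, so this position does respond, and among these four groups only 3-bromophenyl stands apart. The step from compound 2 isolates the change as bromo in place of hydrogen on an aromatic carbon.

From the compounds shown here alone, whether chloro, methyl or an amine in place of bromo would give a similar step stays open. No measurement at hand explains the step.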